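A few compounds are considered here, and "the series" means these few. Any claim that something is new, unique, unknown or untested is made for them only; others in the source may bear on it.

Working notes on the series.

Compound 1 `O=S(=O)(c1ccc(F)c(F)c1)c1cnc2c(F)cccc2c1-c1ccc(Cl)cc1` gives the lowest number of the three measured compounds in an ADME assay on microsomes from liver (Homo sapiens) for metabolic stability, tested at 2.5 uM (a lower number here means slower removal, a higher number faster removal of the compound), at 0.28 mL/min. Compound 2 `O=S(=O)(c1ccc(F)c(F)c1)c1cnc2c(F)cccc2c1-c1ccccc1F` gives 1.39 mL/min in this assay, and compound 3 `O=S(=O)(c1ccc(F)c(F)c1)c1cnc2c(F)cccc2c1-c1cccc(Cl)c1` gives 1.13 mL/min. The two measured steps away from compound 1 both run upward and both fall beyond the scatter: a 5.0-fold higher number from compound 1 to compound 2 (0.70 log units; beyond the scatter), and a 4.0-fold higher number from compound 1 to compound 3 (0.61 log units; beyond the scatter). Between the other two, a 1.2-fold lower number from compound 2 to compound 3 (0.09 log units; within the scatter), which lies within the scatter.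

Compound 4 `O=S(=O)(c1cc(Cl)cc(Cl)c1)c1cnc2c(F)cccc2c1-c1ccc(Cl)cc1` is not yet measured in this assay. The change from compound 1 is 3,5-dichlorophenyl in place of 3,4-difluorophenyl on a sulfonyl sulfur. This alteration sits on the sulfonyl sulfur, whereas every measured step in the series concerns the aryl group on the aromatic carbon of the shared core. Going by the values given here, no measured step therefore bears directly on this change, and the data give no basis for a direction. The expectation for compound 4 is consequently no step beyond the scatter in this assay, with a wide range to reflect the lack of a comparable step; the expected step is a 1.4-fold higher number from compound 1 to compound 4 (0.15 log units; within the scatter). Compound 4 is estimated at 0.4 mL/min, with a range from 0.12 mL/min to 1.3 mL/min.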

Compound 4, intrinsic clearance in a liver preparation (reported as CLH), per the amount of preparation that the assay uses: 0.78 mL/min
Beside the measured number, compound 4's estimate is 2.0-fold (0.29 log units) below it; measured number inside the range.
By their numbers in this assay, from the lowest: compound 1; then compounds 4, 3 and 2 (each within the scatter of the next).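

Going by these compounds alone, the sulfonyl sulfur, untouched by the earlier steps, proves to be a place where a change can move the number in this assay: the exchange of 3,4-difluorophenyl for 3,5-dichlorophenyl gives a 2.8-fold higher number from compound 1 to compound 4 (0.44 log units; beyond the scatter). This change keeps the heavy-atom count, the single six-membered aromatic ring of carbon only, and the counts of hydrogen-bond donors and acceptors, so a step beyond the scatter arises here without any change in those counted features, and compound 1 remains the lowest of the four measured compounds. Nothing available bears on why the number moves at this position.

The exchange alters both the halogen and its placement on the ring, so the compounds shown cannot separate these two parts of the change; a 3,5-difluorophenyl or a 3,4-dichlorophenyl on the sulfonyl sulfur would address that. On these data alone, it also remains open whether the step carries over to the 2-fluorophenyl and 3-chlorophenyl members, and how a saturated amine such as piperidine would read on the sulfonyl sulfur in place of an aryl group.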